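The source may report more compounds than this note shows. Statements on the series, on what has been measured and on what is new or still open speak of the compounds shown alone.

Among the three compounds measured so far, compound 3 `CCc1cc(Nc2nc(N[C@@H](C)C3CCCCC3)nc3ccccc23)n[nH]1` holds the highest number in an assay on isolated protein for inhibition of G protein-coupled receptor kinase 6 (Homo sapiens), read by scintillation counting, radiometric assay and 33P incorporation, with a stated time of 80 min, in the presence of a further agent that is not named here; on this read-out lower numbers stand for stronger inhibition and higher numbers for weaker inhibition: compound 3 gives 960 nM. Compound 1 `CCc1cc(Nc2nc(NCc3ccc(F)cc3)nc3ccccc23)n[nH]1` gives 250 nM, and compound 2 `CCc1cc(Nc2nc(N[C@@H](C)c3ccc(Cl)cc3)nc3ccccc23)n[nH]1` gives 70 nM. The two steps leading to compound 3 were both beyond the scatter: a 3.8-fold higher number from compound 1 to compound 3 (0.58 log units; beyond the scatter) and a 14-fold higher number from compound 2 to compound 3 (1.14 log units; beyond the scatter).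

Compound 4 `CCc1cc(Nc2nc(N[C@H](C)c3ccc(F)cc3)nc3ccccc23)n[nH]1` is reached from compound 3 by one change, (1-(4-fluorophenyl)ethyl in place of 1-cyclohexylethyl on a nitrogen on an aromatic ring). In effect the saturated six-membered ring of compound 3 is swapped back for an aromatic one carrying a fluorine. Within the data shown here, the step that bears most directly on this is the one from compound 2 to compound 3, where an aromatic ring gave way to a saturated one and the number rose by a large margin; the step from compound 1 to compound 3 points the same way with a modest size. Among the measured compounds shown here, compound 4 differs from compound 2 only in the halogen and in the configuration at the stereocentre, and no measured step isolates either of these, so the expected number is placed between compound 1 and compound 2. Compound 4 is therefore expected to show a 7.4-fold lower number from compound 3 to compound 4 (0.87 log units; beyond the scatter), landing at an estimated 130 nM, with a likely range from 45 nM to 400 nM.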

Compound 4, half-maximal inhibitory concentration: 1400 nM
Estimate against measurement, compound 4: 11-fold (1.03 log units) below, and the stated range ends below it.
By their numbers in this assay, from the lowest: compound 2; then compound 1; then compounds 3 and 4 (each within the scatter of the next).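

Swapping 1-cyclohexylethyl for 1-(4-fluorophenyl)ethyl on this nitrogen gives a 1.5-fold higher number from compound 3 to compound 4 (0.16 log units; within the scatter) in this assay, so an aromatic ring at this place does not by itself set a compound apart from one with a saturated ring. Compound 2 keeps an aromatic ring as well, yet the listed step shows a 20-fold higher number from compound 2 to compound 4 (1.30 log units; beyond the scatter) when the chlorine gives way to fluorine and the configuration at the stereocentre also differs, so the strong value of compound 2 depends on at least one of those two features. The added methyl on the chain carbon, in the configuration of compound 4, goes with a 5.6-fold higher number from compound 1 to compound 4 (0.75 log units; beyond the scatter) and so offers no gain over the plain 4-fluorobenzyl group.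

Still open, going by these compounds, is whether the halogen or the configuration carries the large gap, which a 1-(4-chlorophenyl)ethyl group with the configuration of compound 4 could settle, and how a bromine or a methoxy group on the same ring would read. Nothing at hand explains why the numbers fall this way.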